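This account rests on a few compounds, and the source may have more. Where it says the series, first, only, none or still open, it means among the compounds named here.

Working notes on the series.

Of the compounds shown here, three of the shared core have been measured in a functional assay on CHO-K1 cells for antagonist activity at transient receptor potential cation channel subfamily V member 1 (Homo sapiens), read by FLIPR; a higher number here means a weaker inhibitor, a lower number a stronger inhibitor. Compound 1 `CC(C(=O)NCc1ccc(C(F)(F)F)nc1NCC1CCN(C(=O)OC(C)(C)C)CC1)c1ccc(NS(C)(=O)=O)c(F)c1` gives 1140 nM in this assay. Compound 3 `C[C@H](C(=O)NCc1ccc(C(F)(F)F)nc1N1CCC(c2ccccc2)CC1)c1ccc(NS(C)(=O)=O)c(F)c1` gives 17.4 nM in this assay. Compound 2 `CC(C(=O)NCc1ccc(C(F)(F)F)nc1NCc1cccnc1)c1ccc(NS(C)(=O)=O)c(F)c1` is reported in this assay as "not active" (no number reported), so no single number stands for compound 2 and it cannot be placed on the scale against compound 1 or compound 3; it is only known to sit at the weak end of what has been measured.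

Compound 4 `CC(C(=O)NCc1ccc(C(F)(F)F)nc1N1CCC(C(F)(F)F)CC1)c1ccc(NS(C)(=O)=O)c(F)c1` is not yet measured. Against compound 2 the change is 4-(trifluoromethyl)piperidin-1-yl in place of ((pyridin-3-yl)methyl)amino on an aromatic carbon. Within the data shown here, the entering group is of the same kind as the one carried by compound 3, which gives 17.4 nM in this assay, and the leaving group is of the same kind as the one carried by compound 1, which gives 1140 nM in this assay. A step towards stronger inhibition, well beyond the scatter, is therefore expected from compound 2 to compound 4, though its size cannot be counted from an inactive starting point. Compound 4 is expected to give about 80 nM in this assay, in the range 20 nM to 400 nM.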

Compound 4, half-maximal inhibitory concentration: 31 nM
Compound 4: middle estimate off by 2.6-fold (0.41 log units), on the high side, and the stated range covers the measured number.
By their numbers in this assay, from the lowest: compounds 3 and 4 (each within the scatter of the next); then compound 1.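

Compound 2 has no single number in this assay and so the step from it to compound 4 cannot be read. The compounds shown leave open how large that change is when both ends carry numbers. No measurement at hand bears on a cause for this result.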